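The source may hold more compounds than are shown below. What is called first, only, known or untested is meant among the compounds shown, and "the series" means these compounds.

Compound 3 `CC(C)c1ccc(C(=O)NCCCOc2cccc3ccc(N)nc23)cc1` gives 140 nM in a functional assay on IMR-32 cells with melanin-concentrating hormone receptor 1 (Homo sapiens) as the target, read by fluorescence (a lower number here means a stronger inhibitor, a higher number a weaker inhibitor), the second highest of the three numbers; compound 2 `CC(CNCc1ccoc1)Oc1cccc2ccc(N)nc12` gives 100 nM, within the scatter of it, while compound 1 `CC(CN1CCCC1)Oc1cccc2ccc(N)nc12` gives 360 nM. Among the measured compounds shown here, the only measured step, a 3.6-fold lower number from compound 1 to compound 2 (0.56 log units; beyond the scatter), concerns the group on a saturated chain carbon and does not touch the carbonyl end. Compound 4 `Nc1ccc2cccc(OCCCNC(=O)c3cccc(Cl)c3)c2n1` differs from compound 3 by 3-chlorophenyl in place of 4-isopropylphenyl on a carbonyl carbon. For the measured compounds named here, no measured step bears on an exchange at the carbonyl carbon, so for compound 4 the step is expected to be a 1.1-fold higher number from compound 3 to compound 4 (0.03 log units; within the scatter), not clearly beyond the scatter in either direction. Compound 4 is therefore estimated at 150 nM in this assay, with a range from 60 nM to 400 nM.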

Compound 4, half-maximal inhibitory concentration: 3 nM
For compound 4 the middle estimate is 50-fold (1.70 log units) above the measured one; the measured number lies below the stated range.
By their numbers in this assay, from the lowest: compound 4; then compounds 2 and 3 (each within the scatter of the next); then compound 1.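

In this assay, among the compounds shown here, the exchange on the carbonyl carbon gives a 47-fold lower number from compound 3 to compound 4 (1.67 log units; beyond the scatter), so the group at this place, which no earlier step touched, can move the number strongly. For the compounds shown here, the one earlier step, a 3.6-fold lower number from compound 1 to compound 2 (0.56 log units; beyond the scatter), concerned the group on a saturated chain carbon and was modest by comparison. Nothing shown explains the size of this new step. Compound 3 and compound 4 differ in both the isopropyl group and the chlorine, so their separate contributions stay unresolved. As far as these compounds go, how a plain phenyl or a bromophenyl group would read at this place also remains open.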